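Swapping the sulfonamide aryl group in a coumarin-triazole series

A few compounds are considered here, and "the series" means these few. Any claim that something is new, unique, unknown or untested is made for them only; others in the source may bear on it.

Of the compounds shown here, three built on a shared core have been measured in a functional assay on SW-620 cells (Homo sapiens) for inhibition, read by MTT assay, with a stated time of 72 h; a lower number here means a stronger inhibitor, a higher number a weaker inhibitor. Compound 1 `O=c1cc(Cn2cc(-c3cc(F)cc(F)c3)nn2)c2ccc(O)cc2o1` gives 66700 nM in this assay. Compound 2 `CCCCc1ccc(-c2cn(Cc3cc(=O)oc4cc(O)ccc34)nn2)cc1` gives 49200 nM. Compound 3 `Cc1ccc(S(=O)(=O)NCc2cn(Cc3cc(=O)oc4cc(O)ccc34)nn2)cc1` gives 92200 nM. Compound 3 has the highest of the three numbers, yet its distance to compound 1 and its distance to compound 2 both lie within the usual scatter of this assay, so no real order among the three can be read from these numbers.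

Compound 4 `O=c1cc(Cn2cc(CNS(=O)(=O)c3ccc(F)cc3Cl)nn2)c2ccc(O)cc2o1` is not yet measured. It differs from compound 3 in one place: 2-chloro-4-fluorophenyl in place of 4-methylphenyl on a sulfonyl sulfur. The rest of the molecule, the sulfonamide nitrogen, the triazole and the coumarin core, stays as it is.

Within the data shown here, no measured pair in this set differs in a single place, so there is no earlier step to lean on. The change is confined to the ring on the sulfonyl sulfur, and with all three measured compounds sitting close together, the expectation is a step of no size beyond the scatter. On that basis the estimated step of a 1.2-fold lower number from compound 3 to compound 4 (0.06 log units; within the scatter) is small and its direction is uncertain. Compound 4 is therefore expected to give about 80000 nM in this assay, with a range from 30000 nM to 200000 nM.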

Compound 4, half-maximal inhibitory concentration: > 100000 nM
Compound 4: no number, only a limit; the forecaster's own chance of this, stated with the estimate: 25%; at least 1.2-fold (0.09 log units) between middle value and limit.
By their numbers in this assay, from the lowest: compounds 2, 1 and 3 (each within the scatter of the next). At a limit, above all of these: compound 4.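

The result for compound 4 is a limit of the assay and not a number: the limit of > 100000 nM in this assay, at which 1 of the 4 values shown sits.

This gives the set its first comparison of two compounds that differ in one place, and in this assay putting 2-chloro-4-fluorophenyl in place of 4-methylphenyl on the sulfonyl sulfur gives an at least 1.0-fold higher number from compound 3 to compound 4 (0.03 log units; that floor lies within the scatter). So this change of ring brings no gain in this assay, since adding chlorine and fluorine and removing the methyl does not lead to a lower number, although the floor alone does not establish a real loss and the true size of the step remains unknown.

The compounds shown leave open whether chlorine or fluorine alone on this ring would give a different result from the two together, and whether a plain phenyl ring would differ from both rings tested here. They also leave open what a ring carrying an amine or a carboxylic acid would give at this place, or a simple methyl group on the sulfonyl sulfur in place of the ring.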